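The source may hold more compounds than are shown below. What is called first, only, known or untested is meant among the compounds shown, and "the series" means these compounds.

Three compounds were measured in a functional assay on Hep 3B2 cells (Homo sapiens) for antiproliferative activity, read by MTT assay, with a stated time of 24 h, tested at 3.7 ug/mL; a lower number here means a weaker effect, a higher number a stronger effect of the compound at the concentration tested:

compound 1, `CCc1ccc2nc(C(=O)Nc3c(F)cc(-c4cccc(F)c4)cc3F)c(C)c(O)c2c1`, gives 31.2%
compound 2, `COc1ccc2nc(C(=O)Nc3ccc(-c4ccccc4)cc3)c(C)c(O)c2c1`, gives 23.5%
compound 3, `CCc1ccc2nc(C(=O)Nc3c(F)cc(-c4cccc(F)c4)cc3F)c(C)c(C(=O)O)c2c1`, gives 15.2%

Compound 3 arises from compound 1 by one change, (carboxy in place of hydroxy on an aromatic carbon), and this change gave a number 16 percentage points lower from compound 1 to compound 3 (beyond the scatter). Compound 2 has a different core from compound 1; the difference between the two cores is not broken down here. The values of compound 2 and compound 1 lie within the usual scatter of each other.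

Compound 4, `COc1ccc2nc(C(=O)Nc3ccc(-c4ccccc4)cc3)c(C)c(C(=O)O)c2c1`, is not yet measured. It arises from compound 2 by the same change, (carboxy in place of hydroxy on an aromatic carbon), made at the same place. A step of similar size is expected in this assay, a number 15.5 percentage points lower from compound 2 to compound 4 (beyond the scatter), because a number 16 percentage points lower from compound 1 to compound 3 (beyond the scatter) was seen for compound 1. Compound 4 is therefore estimated to give 8%, with a range from 0% to 18%.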

Compound 4, a percentage reported as inhibition, at one concentration (the size of the read-out at that concentration, not a potency): 19.4%
For compound 4 the middle estimate is 11.4 percentage points below the measured one; the measured number lies above the stated range.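

Carboxy in place of hydroxy on the core of compound 2 gives a number 4.1 percentage points lower from compound 2 to compound 4 (within the scatter), so in this assay this pair cannot be told apart. Set beside the earlier step, the new one does not differ from it by more than two such steps can scatter: the same change on two cores in this assay, a number 16 percentage points lower (beyond the scatter) from compound 1 to compound 3 and a number 4.1 percentage points lower (within the scatter) from compound 2 to compound 4, 11.9 percentage points apart, within the scatter of two such steps This fits a step of the same size on both cores, but it equally leaves room for a real difference between them, so two pairs neither prove that the change carries over nor show that the core alters it.

The compounds shown leave open how other groups at this place, such as an amine or a methyl ester, would read in this assay. From the compounds shown here alone, with each compound read at a single concentration, how strong their effect would be at other concentrations also remains open.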